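This account rests on a few compounds, and the source may have more. Where it says the series, first, only, none or still open, it means among the compounds named here.

Measured so far:
Compound 1 `Cc1ccc(S(=O)(=O)c2nc3ccccc3nc2N2CCCC(O)C2)cc1`: in a functional assay on A549 cells (Homo sapiens) for cytotoxicity, read by MTT assay, with a stated time of 72 h (on this read-out higher numbers stand for weaker inhibition and lower numbers for stronger inhibition), compound 1 gives 1350 nM.
Compound 2 `COc1ccc(S(=O)(=O)c2nc3ccccc3nc2N2CCCC(O)C2)cc1`: in this assay compound 2 gives 2180 nM.
Compound 3 `Cc1ccc(S(=O)(=O)c2nc3ccccc3nc2N2CCC(O)CC2)cc1`: in this assay compound 3 gives 4020 nM.

Compound 1 and compound 2 differ by methoxy in place of methyl on an aromatic carbon. That change gives a 1.6-fold higher number from compound 1 to compound 2 (0.21 log units; within the scatter). The cores of compound 1 and compound 3 differ by 4-hydroxypiperidin-1-yl in place of 3-hydroxypiperidin-1-yl on an aromatic carbon, and that rearrangement gives a 3.0-fold higher number from compound 1 to compound 3 (0.47 log units; beyond the scatter). Among the measured compounds shown here, no step is counted between compound 2 and compound 3; their two values lie within the scatter of each other.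

Compound 4 `COc1ccc(S(=O)(=O)c2nc3ccccc3nc2N2CCC(O)CC2)cc1` is not yet measured. It differs from compound 3 by methoxy in place of methyl on an aromatic carbon, the same change already made from compound 1 to compound 2, and the place described for it is the same word for word in both pairs. In this assay the step from compound 3 to compound 4 is expected to be a 1.6-fold higher number from compound 3 to compound 4 (0.20 log units; within the scatter), about the size of a 1.6-fold higher number from compound 1 to compound 2 (0.21 log units; within the scatter); this rests on that single earlier instance, itself within the scatter, so the expectation is weakly held. Compound 4 is estimated at 6400 nM in this assay, with a range from 3200 nM to 13000 nM.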

Compound 4, half-maximal inhibitory concentration: 5110 nM
For compound 4 the middle estimate is 1.3-fold (0.10 log units) above the measured one, and the stated range covers the measured number.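

In this assay, methoxy in place of methyl on an aromatic carbon gives a 1.3-fold higher number from compound 3 to compound 4 (0.10 log units; within the scatter), and its two instances agree: the same change on two cores in this assay, a 1.6-fold higher number (0.21 log units; within the scatter) from compound 1 to compound 2 and a 1.3-fold higher number (0.10 log units; within the scatter) from compound 3 to compound 4, 1.3-fold (0.10 log units) apart, within the scatter of two such steps. Likewise, 4-hydroxypiperidin-1-yl in place of 3-hydroxypiperidin-1-yl on an aromatic carbon gives a 2.3-fold higher number from compound 2 to compound 4 (0.37 log units; beyond the scatter), a step that matches the earlier one: the same change on two cores in this assay, a 3.0-fold higher number (0.47 log units; beyond the scatter) from compound 1 to compound 3 and a 2.3-fold higher number (0.37 log units; beyond the scatter) from compound 2 to compound 4, 1.3-fold (0.10 log units) apart, within the scatter of two such steps. Each change therefore carries between these two cores without a detectable difference, with the hydroxypiperidine change beyond the scatter in both instances, whereas the methoxy change stays within it in both and so is not shown to shift the number at all; four compounds in one assay do not show that either change would carry to any other core.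

Open, on these data alone, is how a chlorine, a nitrile or a longer alkoxy chain would read in place of the methyl or methoxy on the aromatic ring. Also open, as far as these compounds go, is what a primary amine or a carboxylic acid would give in place of the hydroxyl on the piperidine.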